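The source may report more compounds than this note shows. Statements on the series, on what has been measured and on what is new or still open speak of the compounds shown alone.

The measured compounds and their values:

Compound 1, `COc1ccc(/C=C/C2(C)C=CC(=O)O2)c(OC)c1`, in a functional assay on MCF7 cells (Homo sapiens) for inhibition, read by sulforhodamine B assay, with a stated time of 48 h (on this read-out lower numbers stand for stronger inhibition of growth and higher numbers for weaker inhibition of growth), gives 43500 nM.
Compound 2, `COc1ccc(/C=C/C2(C)C=CC(=O)O2)cc1OC`, gives in this assay a value of 78900 nM.
Compound 3, `COc1cc(/C=C/C2(C)C=CC(=O)O2)cc(OC)c1OC`, gives in this assay a value of 56600 nM.

The three compounds share the same core carrying the same substituent groups; compound 1 and compound 2 have the same atoms joined differently, and the difference between their two cores is not broken down here. Compound 1 and compound 3 differ by a gap that is within the scatter, as does the gap between compound 1 and compound 2, so no order among the three can be read from these numbers.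

Among the measured compounds shown here, the only single-point step that is measured is the one from compound 2 to compound 3, where the change is methoxy in place of hydrogen on an aromatic carbon, giving a 1.4-fold lower number from compound 2 to compound 3 (0.14 log units; within the scatter).

Compound 4, `COc1cc(OC)c(/C=C/C2(C)C=CC(=O)O2)c(OC)c1`, has not yet been measured. It differs from compound 1 by methoxy in place of hydrogen on an aromatic carbon. For the measured compounds named here, this is the same kind of change as the one from compound 2 to compound 3, but the surroundings differ: in compound 4 the entering methoxy sits ortho to a group of 9 heavy atoms and meta to two methoxy groups, whereas in compound 3 it sits ortho to a methoxy group, meta to a group of 9 heavy atoms and meta to a methoxy group.

Going by the values given here, because the one measured example of this change, a 1.4-fold lower number from compound 2 to compound 3 (0.14 log units; within the scatter), lies within the scatter, compound 4 is expected to show a step of a 1.1-fold lower number from compound 1 to compound 4 (0.04 log units; within the scatter) in this assay, also within the scatter. On that basis compound 4 is estimated at 40000 nM, with a range from 18000 nM to 90000 nM.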

Compound 4, concentration for total growth inhibition: 102000 nM
The estimate for compound 4 lay 2.6-fold (0.41 log units) below the measured number; the whole stated range lies below it.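

In this assay, methoxy in place of hydrogen on an aromatic carbon gives a 2.3-fold higher number from compound 1 to compound 4 (0.37 log units; beyond the scatter), a modest step but one that lies beyond the scatter. In this series, the size of the step therefore did not carry over unchanged from one core to the other, and the two measured examples differ: the same change on two cores in this assay, a 1.4-fold lower number (0.14 log units; within the scatter) from compound 2 to compound 3 and a 2.3-fold higher number (0.37 log units; beyond the scatter) from compound 1 to compound 4, 3.3-fold (0.51 log units) apart, beyond the scatter of two such steps. This shows only that the outcome of the change depended on where it was made in these two pairs; with two examples, it gives no rule for other cores and does not explain the difference, even though in compound 4 the entering methoxy sits ortho to a group of 9 heavy atoms and meta to two methoxy groups.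

The compounds shown leave open whether a hydroxyl group, an amine or a chlorine atom at the same place on compound 1 would give a step like the one seen with methoxy. They also leave open how a longer chain, such as ethoxy, would behave there, and whether the difference between the two steps would appear again on a further pair of compounds.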